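This account rests on a few compounds, and the source may have more. Where it says the series, first, only, none or still open, it means among the compounds named here.

Of the compounds shown here, three built on one shared core have been measured in an ADME assay on HeLa cells (Homo sapiens) for cytotoxicity, read by sulforhodamine B assay, with a stated time of 48 h, tested at 10 uM; on this read-out higher numbers stand for more inhibition at the one concentration tested (going by the name of the read-out) and lower numbers for less inhibition. Compound 1 `CCCCc1cn(C(c2ccccc2)c2cc3cc(Br)ccc3nc2OC)nn1` gives -2.87%. Compound 2 `CCCCCCCc1cn(C(c2ccccc2)c2cc3cc(Br)ccc3nc2OC)nn1` gives 9.7%. Compound 3 `COc1nc2ccc(Br)cc2cc1C(c1ccccc1)n1cc(-c2cccc(F)c2)nn1` gives 9.04%, which places it second highest of the three numbers: compound 2 lies within the scatter of compound 3, while compound 1 lies beyond it, as the step of a number 11.9 percentage points higher from compound 1 to compound 3 (beyond the scatter) shows. Compound 4 `CCCCCCc1cn(C(c2ccccc2)c2cc3cc(Br)ccc3nc2OC)nn1` has not been measured. It differs from compound 3 by hexyl in place of 3-fluorophenyl on an aromatic carbon. Among the compounds with values here, two measured steps bear on this change. The step of a number 0.7 percentage points lower from compound 2 to compound 3 (within the scatter) shows that heptyl and 3-fluorophenyl give numbers within the scatter of each other, whereas the step of a number 11.9 percentage points higher from compound 1 to compound 3 (beyond the scatter) shows that butyl falls beyond the scatter below 3-fluorophenyl. Hexyl is longer than butyl and shorter than heptyl, and the nearer match is heptyl. Compound 4 is therefore expected to show a step of a number 2 percentage points lower from compound 3 to compound 4 (within the scatter), within the scatter. Compound 4 is estimated at 7%, with a range from -4% to 18%.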

Compound 4, a percentage reported as inhibition, at one concentration (the size of the read-out at that concentration, not a potency): -0.97%
Estimate against measurement, compound 4: 8 percentage points above, and the stated range covers the measured number.
By their numbers in this assay, from the lowest: compounds 1, 4, 3 and 2 (each within the scatter of the next, the first and the last beyond it).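

Hexyl in place of 3-fluorophenyl on this aromatic carbon gives, in this assay, a number 10 percentage points lower from compound 3 to compound 4 (within the scatter), so this change does not separate the two groups, although the step lies close to the edge of the scatter. Among the chains, hexyl stays with butyl, at a number 1.9 percentage points higher from compound 1 to compound 4 (within the scatter), and parts from heptyl, at a number 10.7 percentage points lower from compound 2 to compound 4 (beyond the scatter), which places the only step beyond the scatter in this series of chains between hexyl and heptyl rather than between butyl and hexyl. Nothing available explains why the read-out separates these two chains.

Still open, going by these compounds, is whether a longer chain than heptyl would stay with heptyl or move further along. On these data alone, it is also open how a plain phenyl, or a hexyl chain ending in an amine or a carboxylic acid, would read at this position.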